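A few compounds are considered here, and "the series" means these few. Any claim that something is new, unique, unknown or untested is made for them only; others in the source may bear on it.

Compound 1 `Nc1nc(-c2ccccc2)cn1/N=C/c1cc2ccccc2nc1Cl`: 16400 nM
Compound 2 `Cc1ccc2nc(Cl)c(/C=N/n3cc(-c4ccccc4)nc3N)cc2c1`: 8790 nM
Compound 3 `Nc1nc(-c2ccc3ccccc3c2)cn1/N=C/c1cc2ccccc2nc1Cl`: > 50000 nM

All three values come from a functional assay on DLD-1 cells (Homo sapiens) for cytotoxicity, read by MTT assay, with a stated time of 48 h; on this read-out lower numbers stand for stronger inhibition and higher numbers for weaker inhibition. Among the measured compounds shown here, compound 2 shows the lowest of the two numbers given, and the single measured step, a 1.9-fold lower number from compound 1 to compound 2 (0.27 log units; within the scatter), lies within the scatter. Compound 3 gives no number but only a limit of the assay, (the limit of > 50000 nM in this assay, at which 1 of the 3 values shown sits). Compound 4 `Cc1ccc2nc(Cl)c(/C=N/n3cc(-c4cccc5ccccc45)nc3N)cc2c1` has not yet been measured; it differs from compound 2 by naphthalen-1-yl in place of phenyl on an aromatic carbon. For the measured compounds named here, no measured step covers this exact change. The closest comparison is between compound 1, which gives a number, and compound 3, which gives only a limit after a related enlargement of the same group. The expectation for compound 4 is therefore a higher number in this assay, a 4.6-fold higher number from compound 2 to compound 4 (0.66 log units; beyond the scatter). Compound 4 is expected to give about 40000 nM, within 12000 nM to 150000 nM.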

Compound 4, half-maximal inhibitory concentration: 8300 nM
Compound 4: the middle estimate sits 4.8-fold (0.68 log units) above what was measured; measured number outside the range, below it.
By their numbers in this assay, from the lowest: compounds 4, 2 and 1 (each within the scatter of the next). At a limit, above all of these: compound 3.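

Putting naphthalen-1-yl in place of phenyl on this aromatic carbon of the core of compound 2 gives a 1.1-fold lower number from compound 2 to compound 4 (0.02 log units; within the scatter) in this assay. On this core, then, the position holds two six-membered aromatic rings as well as one, with the two numbers inside the usual scatter. A larger group here therefore does not by itself push the number out of range, although compound 3, on the core of compound 1, gives only a limit: the limit of > 50000 nM in this assay, at which 1 of the 4 values shown sits.

As far as these compounds go, whether naphthalen-1-yl gives a similar number on the core of compound 1 stays open. So does the effect of an amine or a carboxylic acid at this position.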